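Thiourea series: aryl swap on the saturated ring carbon

The compounds below may be only part of what the source reports. "The series", "measured", "known", "first", "only" and "open" are said of these compounds alone.

Among the compounds with values here, compound 2 `COc1cc(/C=C/C(=O)C2=C(/C=C/c3ccc(O)c(OC)c3)NC(=S)NC2c2ccccc2O)ccc1O` gives 79.9% in a functional assay, with a stated time of 20 min, tested at 20 uM (a lower number here means a weaker effect, a higher number a stronger effect of the compound at the concentration tested), the highest of the two numbers so far. Compound 1 `COc1cc(/C=C/C(=O)C2=C(/C=C/c3ccc(O)c(OC)c3)NC(=O)NC2c2ccccc2Cl)ccc1O` gives 38.7% in this assay, beyond the scatter lower, but the two structures differ in more than one place, so only their two values can be set side by side. Compound 3 `COc1cc(/C=C/C(=O)C2=C(/C=C/c3ccc(O)c(OC)c3)NC(=S)NC2c2c(Cl)cccc2Cl)ccc1O` is not yet measured; it carries 2,6-dichlorophenyl in place of 2-hydroxyphenyl on a saturated ring carbon. With compound 1 at 38.7% as the only point bearing chlorine at that ring carbon, a decrease beyond the scatter is expected, though smaller than that gap. Compound 3 is estimated at 58%, with a range from 30% to 85%. The expected step of a number 21.9 percentage points lower from compound 2 to compound 3 (beyond the scatter) is thus downward.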

Compound 3, a percentage reported as activity, at one concentration (the size of the read-out at that concentration, not a potency): 33.9%
Compound 3: middle estimate off by 24.1 percentage points, on the high side, and the stated range covers the measured number.
By their numbers in this assay, from the lowest: compounds 3 and 1 (each within the scatter of the next); then compound 2.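

With the rest of the structure held constant, 2,6-dichlorophenyl in place of 2-hydroxyphenyl on the saturated ring carbon gives a number 46 percentage points lower from compound 2 to compound 3 (beyond the scatter) in this assay. Within the data shown here, this is the first single-place comparison, and it shows that the read-out at the concentration tested responds strongly to the aryl group at this position. No measurement at hand bears on the reason for the step.

On these data alone, whether the loss of the hydroxyl or the gain of the two chlorines carries the step stays open. An unsubstituted phenyl or a 2-methoxyphenyl at this carbon would help separate the two.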